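The compounds below may be only part of what the source reports. "The series", "measured", "known", "first", "only" and "open" are said of these compounds alone.

Measured so far in a functional assay on ECa-109 cells for inhibition, with ECa-109 cell line (Homo sapiens) as the target, read by sulforhodamine B assay; a lower number here means a stronger inhibitor, a higher number a weaker inhibitor:

Compound 1, `CCc1ccc(NC2=CC(=O)c3c(nc4n3[C@H]3OC[C@@H](O)[C@H]3OC4)C2=O)cc1`. In this assay compound 1 gives > 4000 nM, which is a limit of the assay and not a number.
Compound 2, `Cc1ccc(NC2=CC(=O)c3c(nc4n3[C@H]3OC[C@@H](O)[C@H]3OC4)C2=O)cc1`. In this assay compound 2 gives > 4000 nM, likewise a limit and not a number.
Compound 3, `COc1ccc(NC2=CC(=O)c3c(nc4n3[C@H]3OC[C@@H](O)[C@H]3OC4)C2=O)cc1`. In this assay compound 3 gives 3410 nM.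

Among the compounds with values here, compound 3 carries the only number in the set; the other two values are the limit of > 4000 nM in this assay, at which 2 of the 3 values shown sit. The steps of an at least 1.1-fold lower number from compound 1 to compound 3 (0.06 log units; that floor lies within the scatter) and an at least 1.1-fold lower number from compound 2 to compound 3 (0.06 log units; that floor lies within the scatter) are therefore floors only, and both floors lie within the scatter, so no ordering among the three is readable. The cores of compound 2 and compound 3 differ by methoxy in place of methyl on an aromatic carbon.

Compound 4, `CCOc1ccc(NC2=CC(=O)c3c(nc4n3[C@H]3OC[C@@H](O)[C@H]3OC4)C2=O)cc1`, is not yet measured. It differs from compound 3 by methyl in place of hydrogen on a saturated chain carbon bound to an oxygen on an aromatic ring. The same kind of change occurs once more in the set, from compound 2 to compound 1: methyl in place of hydrogen on a saturated chain carbon bound to an aromatic carbon. The place is not the same: there the carbon is bound to an aromatic carbon, here it is bound to an oxygen on an aromatic ring. The step that the two limits leave unreadable from compound 2 to compound 1 gives no size, since both ends are limits, so the precedent offers no direction.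

Within the data shown here, with the only precedent unreadable, the expectation for compound 4 rests on compound 3 alone and on the fact that two of the three measured values sit at the limit. A step of a 1.2-fold higher number from compound 3 to compound 4 (0.07 log units; within the scatter) is expected, meaning little change from compound 3. Compound 4 is estimated at 4000 nM, within 1500 nM to 12000 nM, with a real chance that only a limit is reported.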

Compound 4, half-maximal inhibitory concentration: > 4000 nM
Compound 4 gave a limit, no number (the forecaster's own chance of this, stated with the estimate: 55%); the middle value sits exactly at the limit.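

In this assay compound 4 gives > 4000 nM, which is a limit of the assay and not a number. Going from methoxy to ethoxy gives an at least 1.1-fold higher number from compound 3 to compound 4 (0.06 log units; that floor lies within the scatter), so this is a floor only and neither the size nor the direction of the change can be read on this core. The same kind of change at the carbon bound to an aromatic carbon, from compound 2 to compound 1, cannot be read, and neither can the steps from compound 2 and from compound 1 to compound 4, so nothing shows whether the change carries from one place to another or to a different core, and the set offers almost no numbers to compare: the limit of > 4000 nM in this assay, at which 3 of the 4 values shown sit.

As far as these compounds go, it stays open whether an amine, a carboxylic acid or a longer chain such as butoxy, in place of the ethoxy of compound 4, would give a number rather than a limit in this assay. From the compounds shown here alone, it also stays open whether the methoxy to ethoxy change would have a readable size on a core whose values lie clear of that limit.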